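Halogen Swap on the Benzylidene Ring: Compound 3

A few compounds are considered here, and "the series" means these few. Any claim that something is new, unique, unknown or untested is made for them only; others in the source may bear on it.

Compound 2 `C=CCn1c(=O)/c(=C\c2cccc(F)c2)[nH]c(=O)/c1=C\c1ccccc1OC` gives the highest of the two numbers recorded so far in a functional assay on U-937 cells (Homo sapiens) for cytotoxicity, read by CCK-8 assay, with a stated time of 72 h (on this read-out higher numbers stand for weaker inhibition and lower numbers for stronger inhibition), at 2500 nM. For the measured compounds named here, its only neighbour is compound 1 `C=CCn1c(=O)/c(=C\c2cccc(Cl)c2)[nH]c(=O)/c1=C\c1ccccc1OC`, which in this assay gives 1200 nM; the single measured step, a 2.1-fold higher number from compound 1 to compound 2 (0.32 log units; beyond the scatter), is the fluoro-for-chloro exchange on an aromatic carbon.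

Compound 3 `C=CCn1c(=O)/c(=C\c2ccccc2Cl)[nH]c(=O)/c1=C\c1ccccc1OC` is not yet measured. Relative to compound 2 the change is 2-chlorophenyl in place of 3-fluorophenyl on a double-bonded chain carbon bound to an aromatic carbon. Going by the values given here, this partly reverses the measured step, since chlorine returns in place of fluorine, but the entering ring is 2-chlorophenyl and not the ring of compound 1, so no measured step covers the ring itself. The measured step, a 2.1-fold higher number from compound 1 to compound 2 (0.32 log units; beyond the scatter), was modest and beyond the scatter; its reversal points to a lower number for compound 3 of about that size, while the untested ring change leaves the outcome less certain. The expectation is therefore a modest fall in this assay, a 1.7-fold lower number from compound 2 to compound 3 (0.22 log units; within the scatter), though a result within the scatter of compound 2 would not surprise. Compound 3 is estimated at 1500 nM, with a range from 500 nM to 4500 nM.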

Compound 3, half-maximal inhibitory concentration: 700 nM
The estimate for compound 3 lay 2.1-fold (0.33 log units) above the measured number, within the range that was stated.
By their numbers in this assay, from the lowest: compounds 3 and 1 (each within the scatter of the next); then compound 2.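

In this assay, the step of a 1.7-fold lower number from compound 1 to compound 3 (0.23 log units; within the scatter) lies within the scatter, so 2-chlorophenyl and 3-chlorophenyl on a double-bonded chain carbon bound to an aromatic carbon cannot be told apart on this read-out. The exchange of 3-fluorophenyl for 2-chlorophenyl at the same place gives a 3.6-fold lower number from compound 2 to compound 3 (0.55 log units; beyond the scatter) and lies beyond the scatter, which, read with a 2.1-fold higher number from compound 1 to compound 2 (0.32 log units; beyond the scatter) from the earlier pair, leaves the 3-fluorophenyl compound apart from both chlorophenyl compounds among the three shown. Nothing available on these compounds bears on what lies behind this difference.

Whether the gap for compound 2 follows the halogen or its place on the ring stays open, as the compounds shown include no 2-fluorophenyl ring that would separate the two. Also open, going by these compounds, is how this place responds to rings without a halogen, such as an unsubstituted phenyl, a methoxyphenyl or an aminophenyl ring, or to a ring carrying a carboxylic acid.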